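Working notes on a hydroxyphenyl-for-fluorophenyl exchange

The compounds below may be only part of what the source reports. "The series", "measured", "known", "first", "only" and "open" are said of these compounds alone.

Compound 1 `CC(C)(C)C1=NN(c2ccc(C(F)(F)F)cc2)C(c2ccc(O)cc2)C1`: in an assay on isolated protein for inhibition of protein kinase C zeta type (Homo sapiens), with a stated time of 4 min (a lower number here means a stronger inhibitor, a higher number a weaker inhibitor), compound 1 gives 8800 nM.
Compound 2 `CC(C)(C)C1=NN(c2ccc(Cl)cc2)C(c2ccc(F)cc2)C1`: in this assay compound 2 gives "not determined" (no result reported), so no result is reported for it.

Compound 2 therefore stands nowhere on the numbers: no single value exists for it in this assay, and the only measured anchor in the series is compound 1. Compound 3 `CC(C)(C)C1=NN(c2ccc(Cl)cc2)C(c2ccc(O)c(Cl)c2)C1` differs from compound 2 in one place, (3-chloro-4-hydroxyphenyl in place of 4-fluorophenyl on a saturated ring carbon), that is, 3-chloro-4-hydroxyphenyl in place of 4-fluorophenyl on a saturated ring carbon. With no number for compound 2, the size and direction of the step to compound 3 in this assay cannot be stated from the data; no shift beyond the scatter is asserted. The expectation for compound 3 rests on compound 1, which shares the hydroxyphenyl group and gives 8800 nM in this assay. Compound 3 is expected to give 5000 nM, with an estimated range of 1500 nM to 20000 nM.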

Compound 3, half-maximal inhibitory concentration: 700 nM
For compound 3 the middle estimate is 7.1-fold (0.85 log units) above the measured one; measured number outside the range, below it.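

Among the compounds shown here, compound 2 has no number in this assay, so no step to compound 3 can be read. The compounds shown leave open what the 3-chloro-4-hydroxyphenyl group contributes relative to 4-fluorophenyl on the shared core. Nothing shown bears on a cause for the result of compound 3.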